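Moving the ring nitrogen of a pyridyl piperazine amide

The source may hold more compounds than are shown below. What is called first, only, known or untested is meant among the compounds shown, and "the series" means these compounds.

Compound 1, `CC#CC(CC(=O)O)c1ccc(OCc2ccc(C(=O)N3CCN(C)CC3)s2)cc1`: in a functional assay on HEK293 cells for agonist activity at Free fatty acid receptor 1 (Homo sapiens), read by fluorescence and calcium flux (on this read-out lower numbers stand for an effect already at smaller amounts and higher numbers for an effect only at larger amounts of compound), compound 1 gives > 5000 nM, which is a limit of the assay and not a number.
Compound 2, `CC#CC(CC(=O)O)c1ccc(OCc2ccc(C(=O)N3CCN(c4ccncc4)CC3)s2)cc1`: in this assay compound 2 gives > 5000 nM, again a limit of the assay and not a number.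

Compound 2 therefore stands at the limit only; on the numbers shown it has no readable position, and the one step that leads to it, a step that the two limits leave unreadable from compound 1 to compound 2, is left without a size by the two limits. For the measured compounds named here, the only evidence is the limit of > 5000 nM in this assay, at which 2 of the 2 values shown sit.

Compound 3, `CC#CC(CC(=O)O)c1ccc(OCc2ccc(C(=O)N3CCN(c4cccnc4)CC3)s2)cc1`, is not yet measured. It differs from compound 2 in one place: pyridin-3-yl in place of pyridin-4-yl on an amine nitrogen in a ring. Going by the values given here, no measured step bears on this change, and the single measured step, from the methyl to the pyridin-4-yl compound, has no readable size. With both neighbours at the limit, the expectation for compound 3 is that it too remains at the limit, so the step that the limit leaves unreadable from compound 2 to compound 3 is estimated to be none beyond the scatter. The estimate for compound 3 in this assay is 9000 nM, with a range from 3000 nM to 40000 nM.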

Compound 3, half-maximal effective concentration: 1140 nM
Estimate against measurement, compound 3: 7.9-fold (0.90 log units) above; measured number outside the range, below it.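

In this assay, the change of pyridin-4-yl to pyridin-3-yl on the amine nitrogen in the ring gives an at least 4.3-fold lower number from compound 2 to compound 3 (0.64 log units; beyond the scatter). The two groups hold the same atoms, joined differently, so this position responds to how the group is joined and not only to which atoms it contains. Replacing the methyl group with pyridin-3-yl gives an at least 4.3-fold lower number from compound 1 to compound 3 (0.64 log units; beyond the scatter), which makes compound 3 the only one of the three with a readable number, and the sizes of both new steps are minimum sizes, while the step from compound 1 to compound 2 cannot be read: the limit of > 5000 nM in this assay, at which 2 of the 3 values shown sit.

With a single readable number, the compounds shown leave open how far compound 3 truly lies from compound 1 and compound 2, and they do not say why moving the ring nitrogen matters. They also leave open whether pyridin-2-yl or an unsubstituted phenyl group on the same amine nitrogen would give a number as low as that of compound 3 or would stay at the limit of the assay.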